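A Piperazine Amide Loses Its Pyridinyl Group

This account rests on a few compounds, and the source may have more. Where it says the series, first, only, none or still open, it means among the compounds named here.

Of the compounds shown here, three sharing one core have been tested in a functional assay on HeLa cells (Homo sapiens) for antiproliferative activity, read by sulforhodamine B assay, with a stated time of 48 h; a higher number here means a weaker inhibitor, a lower number a stronger inhibitor. Compound 1 `COc1ccc(CNC(=O)/C=C/C=C/[C@H](O)Cc2ccc(OC)c(OC)c2)cc1` gives 9450 nM. Within the data shown here, compound 3 `COc1ccc(C[C@@H](O)/C=C/C=C/C(=O)NCc2ccc(Cl)cc2)cc1OC` gives 13400 nM; the only single-point step among them, a 1.4-fold higher number from compound 1 to compound 3 (0.15 log units; within the scatter), sits on the aromatic ring of the amide side chain. Compound 2 `COc1ccc(C[C@@H](O)/C=C/C=C/C(=O)N2CCN(c3ccccn3)CC2)cc1OC` gives 23600 nM, the highest number of the three: against compound 3 the gap is within the scatter, against compound 1 it lies beyond it.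

Compound 4 `COc1ccc(C[C@@H](O)/C=C/C=C/C(=O)N2CCN(C)CC2)cc1OC` has not yet been measured. It differs from compound 2 by methyl in place of pyridin-2-yl on an amine nitrogen in a ring.

Among the measured compounds shown here, no measured step touches this part of the molecule: the only step available concerns the aromatic ring on the other side of the amide and was itself within the scatter. The data therefore give no ground to expect compound 4 to move beyond the scatter in either direction in this assay. Compound 4 is estimated to give 25000 nM, with a range from 8000 nM to 70000 nM, meaning an expected step of a 1.1-fold higher number from compound 2 to compound 4 (0.03 log units; within the scatter).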

Compound 4, half-maximal inhibitory concentration: 16500 nM
Compound 4: middle estimate off by 1.5-fold (0.18 log units), on the high side, and the stated range covers the measured number.
By their numbers in this assay, from the lowest: compounds 1, 3, 4 and 2 (each within the scatter of the next, the first and the last beyond it).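

In this assay, exchanging the whole pyridin-2-yl ring on the amine nitrogen for a single methyl gives a step that stays within the scatter (a 1.4-fold lower number from compound 2 to compound 4 (0.16 log units; within the scatter)), so this first change at this position separates neither compound from the other. A change to the entire group on the carbonyl carbon, 4-methylpiperazin-1-yl in place of (4-chlorobenzyl)amino, also stays within the scatter (a 1.2-fold higher number from compound 3 to compound 4 (0.09 log units; within the scatter)), so these two amide groups cannot be told apart in this assay. No independent data offer an explanation for either step.

The compounds shown leave open whether a benzyl group, or a longer chain ending in a carboxylic acid, on that ring nitrogen would move the number beyond the scatter. The same question stands for a plain hydrogen on that nitrogen.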